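Notes on a fluoro step across two cores

The source may hold more compounds than are shown below. What is called first, only, known or untested is meant among the compounds shown, and "the series" means these compounds.

Compound 1 `O=c1c(C2N=C(c3ccccc3)SS2)coc2cc(Cl)ccc12` and compound 2 `O=c1c(C(=S)Nc2ccccc2)coc2ccccc12` carry different cores; the difference between the two cores is not broken down here. In a functional assay on IMR-32 cells (Homo sapiens) for inhibition, read by sulforhodamine B assay, with a stated time of 48 h, tested at 100 uM (a higher number here means more inhibition of growth at the concentration tested, a lower number less inhibition of growth), compound 1 gives 53% and compound 2 gives 53%. Compound 3 `O=c1c(C(=S)Nc2ccccc2)coc2ccc(F)cc12` carries fluoro in place of hydrogen on an aromatic carbon relative to compound 2, and in this assay compound 3 gives 59%; the step is a number 6 percentage points higher from compound 2 to compound 3 (within the scatter). Compound 4 `O=c1c(C2N=C(c3ccccc3)SS2)coc2cc(Cl)c(F)cc12` carries fluoro in place of hydrogen on an aromatic carbon relative to compound 1, the same kind of change, here ortho to a chloro group (1 heavy atom), which compound 3 does not have. Because the step of a number 6 percentage points higher from compound 2 to compound 3 (within the scatter) stays within the scatter, the step from compound 1 to compound 4 is expected to be of about the same size, a number 5 percentage points higher from compound 1 to compound 4 (within the scatter). Compound 4 is estimated at 58%, between 45% and 70%.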

Compound 4, percent growth inhibition at one concentration: 80%
Compound 4: middle estimate off by 22 percentage points, on the low side, outside the stated range (above it).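

In this assay the fluoro step does not carry over at one size between the two cores: the same change on two cores in this assay, a number 6 percentage points higher (within the scatter) from compound 2 to compound 3 and a number 27 percentage points higher (beyond the scatter) from compound 1 to compound 4, 21 percentage points apart, beyond the scatter of two such steps. The larger step is a number 27 percentage points higher from compound 1 to compound 4 (beyond the scatter) and places the fluoro ortho to a chloro group, which compound 3 does not have. With a single pair on each core, this shows that the step cannot be transferred at face value, but not whether the core, the chloro group or both account for the gap.

Still open, as far as these compounds go, is whether an amine or a methoxy group in place of the fluoro would also differ between the two cores. Also open, from the compounds shown here alone, is what fluoro does on the core of compound 1 without the chloro group.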